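Cytotoxicity check: methoxyphenyl urea in place of dichlorophenyl urea

This account rests on a few compounds, and the source may have more. Where it says the series, first, only, none or still open, it means among the compounds named here.

Compound 3 `O=C(NCCNS(=O)(=O)c1ccc(-c2ccccc2OCc2cccc(O)c2)s1)Nc1cc(Cl)cc(Cl)c1` reports only a limit in an ADME assay on HEK-293T cells (Homo sapiens) for cytotoxicity, read by CCK-8 assay, with a stated time of 48 h (on this read-out lower numbers stand for stronger inhibition and higher numbers for weaker inhibition), namely > 20000 nM. Compound 1 `O=C(NCCNS(=O)(=O)c1ccc(-c2ccccc2O[C@H]2CC[C@H](O)CC2)s1)Nc1cc(Cl)cc(Cl)c1` also gives only a limit in this assay, > 50000 nM. Compound 2 `COc1ccc(NC(=O)NCCNS(=O)(=O)c2ccc(-c3ccccc3Oc3ccc([N+](=O)[O-])cc3)s2)cc1` likewise sits at a limit in this assay, > 20000 nM. Among the compounds with values here, the one measured step, a step that the two limits leave unreadable from compound 1 to compound 3, is not readable because the limit of > 20000 nM in this assay, at which 2 of the 3 values shown sit, and the limit of > 50000 nM in this assay, at which 1 of the 3 values shown sits, are both limits. Compound 4 `COc1ccc(NC(=O)NCCNS(=O)(=O)c2ccc(-c3ccccc3OCc3cccc(O)c3)s2)cc1` differs from compound 3 by 4-methoxyphenyl in place of 3,5-dichlorophenyl on an amide-type nitrogen. Compound 2 already carries the entering group and shows no measurable cytotoxicity. Within the data shown here, no measured step bears on the change in readable size, so no step beyond the scatter is expected in this assay. The expected step is a step that the limit leaves unreadable from compound 3 to compound 4. Compound 4 is therefore expected at 50000 nM, within 20000 nM to 200000 nM, most likely again reported only as a limit.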

Compound 4, half-maximal inhibitory concentration: > 20000 nM
Compound 4: no number, only a limit; the forecaster's own chance of this, stated with the estimate: 90%; the middle value lies beyond the limit too.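

Within the data shown here, compound 4 gives > 20000 nM in this assay and this is a limit, so no step from compound 3 or compound 2 to compound 4 can be read. The compounds shown leave open at which concentration, if any, each becomes cytotoxic.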